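Acetyl in place of a nitrogen-bearing group: compound 3

A few compounds are considered here, and "the series" means these few. Any claim that something is new, unique, unknown or untested is made for them only; others in the source may bear on it.

Compound 1 `CCn1c(SCC(=O)Nc2ccc(C(C)=O)cc2)nnc1-c1ccc(OC)c(OC)c1` gives 66% in a functional assay on the whole organism (strain albino) for inhibition, with Rattus norvegicus as the target, read by paw edema, with stated times of 30 min and 5 h, at a dose of 0.28 mmol/kg by the oral route; on this read-out higher numbers stand for more inhibition at the one dose given (going by the name of the read-out) and lower numbers for less inhibition. Compound 2 `CCn1c(SCC(=O)Nc2ccc(/C(C)=N/O)cc2)nnc1-c1ccccc1` gives 66% in this assay, level with compound 1 at the digits shown, the gap lying within the scatter. Compound 3 `CCn1c(SCC(=O)Nc2ccc(C(C)=O)cc2)nnc1-c1ccccc1` is not yet measured; against compound 2 it carries a group of 3 heavy atoms (2 carbon, 1 oxygen; no ring) in place of a group of 4 heavy atoms (2 carbon, 1 nitrogen, 1 oxygen; no ring), on an aromatic carbon. Compound 3 shares its acetyl with compound 1, and since compound 1 at 66% stands level with compound 2 at 66%, no step beyond the scatter is expected in this assay. Compound 3 is estimated at 66%, with a range from 52% to 78%. The step of no change at the digits printed from compound 2 to compound 3 (within the scatter) is expected to stay within the scatter.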

Compound 3, a percentage reported as inhibition, in the whole organism at one dose (the size of the read-out at that dose, not a potency): 66%
The estimate for compound 3 equals the measured number at the digits printed; the range from low to high includes it.
By their numbers in this assay, from the lowest: compounds 1, 2 and 3 (each within the scatter of the next).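

Read in this assay the exchange of the nitrogen-bearing group for acetyl on the aromatic carbon gives no change at the digits printed from compound 2 to compound 3 (within the scatter) and so, with phenyl in common, compares these two groups directly for the first time. Phenyl in place of 3,4-dimethoxyphenyl gives no change at the digits printed from compound 1 to compound 3 (within the scatter) and does so with acetyl in common, so neither change separates the compounds at this one dose. No data bearing on the cause of these results are available.

From the compounds shown here alone, whether an amine or a carboxylic acid on this aromatic carbon would hold the read-out stays open. A single dose also leaves any difference in potency among these compounds unresolved.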